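Two methoxy groups added to an inactive indole acrylic acid

The source may report more compounds than this note shows. Statements on the series, on what has been measured and on what is new or still open speak of the compounds shown alone.

The series shares a core carrying an acrylic acid, a benzyloxy-substituted indole and an aryl group on the double-bonded chain carbon. Compound 2 is `CC(=O)n1cc(/C=C(/C(=O)O)c2ccccc2)c2cc(OCc3ccccc3)ccc21`. In a functional assay on M14 cells (Homo sapiens) for cytotoxicity, read by MTT assay, with a stated time of 72 h (on this read-out lower numbers stand for stronger inhibition and higher numbers for weaker inhibition), compound 2 gives > 100000 nM, which is a limit of the assay rather than a number. Compound 1 is `COc1cccc(/C(=C\c2cn(C(C)=O)c3ccc(OCc4ccccc4)cc23)C(=O)O)c1`. In this assay compound 1 also gives > 100000 nM, again a limit. The step from compound 1 to compound 2, hydrogen in place of methoxy on an aromatic carbon, is therefore a step that the two limits leave unreadable from compound 1 to compound 2. Compound 3 is `COc1ccc(/C(=C\c2c[nH]c3ccc(OCc4ccccc4)cc23)C(=O)O)cc1`, which differs in two places from the others, and in this assay compound 3 gives 58400 nM.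

Compound 4 is `COc1ccc(OC)c(/C(=C\c2cn(C(C)=O)c3ccc(OCc4ccccc4)cc23)C(=O)O)c1`. It differs from compound 2 by 2,5-dimethoxyphenyl in place of phenyl on a double-bonded chain carbon bound to a carbonyl carbon and a double-bonded chain carbon. For the measured compounds named here, the one comparable step, adding a single methoxy, gave no readable change (the limit of > 100000 nM in this assay, at which 2 of the 3 values shown sit), so no step beyond the scatter is expected; the estimated step of a number no higher from compound 2 to compound 4 (the limit leaves the size open) is small. Compound 4 is therefore expected to give about 100000 nM, within a range from 30000 nM to 300000 nM, most likely again only as a limit.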

Compound 4, half-maximal inhibitory concentration: 87100 nM
Beside the measured number, compound 4's estimate is 1.1-fold (0.06 log units) above it, within the range that was stated.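

Replacing phenyl with 2,5-dimethoxyphenyl on this double-bonded chain carbon yields a readable number rather than a limit: in this assay compound 4 gives 87100 nM as a true value. The change produces an at least 1.1-fold lower number from compound 2 to compound 4 (0.05 log units; that floor lies within the scatter) and adding a methoxy on an aromatic carbon produces an at least 1.1-fold lower number from compound 1 to compound 4 (0.05 log units; that floor lies within the scatter), so neither step shows a real gain in potency. Each step is only a floor with a limit at one end, which leaves its true size unknown: the limit of > 100000 nM in this assay, at which 2 of the 4 values shown sit.

The compounds shown leave open how much each of the two methoxy groups contributes to the true size of this step. They also leave open whether a hydroxyl group or an amine on the same aryl ring would give a number clearly beyond the scatter.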